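The source may hold more compounds than are shown below. What is called first, only, known or untested is meant among the compounds shown, and "the series" means these compounds.

Going by the values given here, in a functional assay on HCT-116 cells (Homo sapiens) for antiproliferative activity, read by MTT assay, with a stated time of 48 h (on this read-out lower numbers stand for stronger inhibition and higher numbers for weaker inhibition), compound 1 `CCOc1cc(-c2ccc3c(ccn3C)c2)cn2c(-c3cc(OC)c(OC)c(OC)c3)nnc12` gives 228 nM, while compound 2 `COc1cc(-c2nnc3c(OC)cc(-c4ccc5c(ccn5C)c4)cn23)cc(OC)c1OC` gives 33 nM, the lower of the two numbers so far. Compound 3 `COc1cc(-c2nnc3c(OC(C)C)cc(-c4ccc5c(ccn5C)c4)cn23)cc(OC)c1OC` changes compound 2 in one place: isopropyl in place of methyl on an oxygen on an aromatic ring. Among the compounds with values here, one measured step bears on this: a 6.9-fold lower number from compound 1 to compound 2 (0.84 log units; beyond the scatter), with hydrogen in place of methyl on a saturated chain carbon bound to an oxygen on an aromatic ring. Adding carbon there went with a higher number, so a clear rise is expected in this assay. The expected step is a 15-fold higher number from compound 2 to compound 3 (1.18 log units; beyond the scatter). For compound 3, the estimate is 500 nM, with an expected range of 150 nM to 1800 nM.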

Compound 3, half-maximal inhibitory concentration: 402 nM
Compound 3: middle estimate off by 1.2-fold (0.09 log units), on the high side; the range from low to high includes it.
By their numbers in this assay, from the lowest: compound 2; then compounds 1 and 3 (each within the scatter of the next).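

Replacing methoxy with isopropoxy in this assay gives a 12-fold higher number from compound 2 to compound 3 (1.09 log units; beyond the scatter), a large loss at this oxygen. The further methyl on the chain carbon gives a 1.8-fold higher number from compound 1 to compound 3 (0.25 log units; within the scatter), so compound 1 and compound 3 cannot be told apart, and the rise does not keep growing with each added carbon. Among these three compounds, the methoxy of compound 2 gives the lowest number.

Going by these compounds, how a hydroxyl group or a longer chain carrying an amine would behave at this oxygen remains open. No measurement shown here explains these steps.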